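Side chain on the sulfur: working notes toward compound 4

This account rests on a few compounds, and the source may have more. Where it says the series, first, only, none or still open, it means among the compounds named here.

Measured so far in a functional assay on HT cells (Homo sapiens) for antiproliferative activity, read by fluorescence, with a stated time of 72 h; on this read-out higher numbers stand for weaker inhibition of growth and lower numbers for stronger inhibition of growth:
compound 1 `CC(C)c1n[nH]c2c(NCc3ccc(-c4ccccn4)cc3)nc(SCCC(N)=O)nc12` gives 120 nM
compound 2 `CC(C)c1n[nH]c2c(NCc3ccc(-c4ccccn4)cc3)nc(SCC(O)CN)nc12` gives 55 nM
compound 3 `CC(O)CSc1nc(NCc2ccc(-c3ccccn3)cc2)c2[nH]nc(C(C)C)c2n1` gives 62 nM

All three share the same core and differ only in the chain carried on the sulfur. Compound 2 sits at the low end of the three numbers in this assay: a 1.1-fold higher number from compound 2 to compound 3 (0.05 log units; within the scatter) stays within the scatter, whereas a 2.2-fold lower number from compound 1 to compound 2 (0.34 log units; beyond the scatter) lies beyond it, so compound 2 is separated from compound 1 but not from compound 3.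

The next compound, compound 4 `CC(C)c1n[nH]c2c(NCc3ccc(-c4ccccn4)cc3)nc(SC(C)C(C)O)nc12`, changes the chain on the sulfur once more. 2-hydroxy-1-methylpropyl in place of 3-amino-2-hydroxypropyl on a sulfur

Among the measured compounds shown here, only one measured step touches this change. From compound 2 to compound 3 the amino is dropped and the number moves by a 1.1-fold higher number from compound 2 to compound 3 (0.05 log units; within the scatter), within the scatter. For the measured compounds named here, no measured pair speaks to the shorter chain or to the methyl on the sulfur-bound carbon that enters in compound 4. The removal of the amino therefore gives no reason to expect a shift beyond the scatter, and the untested part of the change is taken as a source of uncertainty rather than of a predicted direction.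

The step from compound 2 to compound 4 is expected to be a 1.5-fold higher number from compound 2 to compound 4 (0.16 log units; within the scatter) in this assay. Compound 4 is estimated at 80 nM, with a range from 35 nM to 200 nM.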

Compound 4, concentration for 50% growth inhibition: 190 nM
The estimate for compound 4 lay 2.4-fold (0.38 log units) below the measured number; low and high end bracket the measured number.
By their numbers in this assay, from the lowest: compounds 2, 3, 1 and 4 (each within the scatter of the next, the first and the last beyond it).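

In this assay, among the compounds shown here, the chain on the sulfur responds to a change the earlier compounds did not touch, since methyl in place of hydrogen on the saturated chain carbon bound to a saturated chain carbon and a sulfur gives a 3.1-fold higher number from compound 3 to compound 4 (0.49 log units; beyond the scatter) and so moves the number beyond the scatter, which dropping the amino did not do. The full exchange of 3-amino-2-hydroxypropyl for 2-hydroxy-1-methylpropyl gives a 3.5-fold higher number from compound 2 to compound 4 (0.54 log units; beyond the scatter) and is of similar size, so in these compounds the shift goes with the added methyl and not with the lost amino. The 2-carbamoylethyl chain of compound 1 stays unseparated from this new chain, with a 1.6-fold higher number from compound 1 to compound 4 (0.20 log units; within the scatter) and thus within the scatter, and nothing available explains why the methyl carries this step.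

Open, going by these compounds, is whether the methyl has the same effect with the amino kept, as in a 3-amino-2-hydroxy-1-methylpropyl chain. Also open, on these data alone, is how an ethyl on that same carbon, a carboxylic acid at the chain end or a longer chain would read in this assay on the shared core.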